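Cyclising the aminoethyl sulfur chain: expected growth inhibition

A few compounds are considered here, and "the series" means these few. Any claim that something is new, unique, unknown or untested is made for them only; others in the source may bear on it.

Within the data shown here, compound 2 `CC(C)c1n[nH]c2c(NCc3ccc(-c4ccccn4)cc3)nc(SCCN)nc12` gives the lowest of the two numbers so far in a functional assay on HT cells (Homo sapiens) for antiproliferative activity, read by fluorescence, with a stated time of 72 h (a lower number here means a stronger inhibitor of growth, a higher number a weaker inhibitor of growth), reading 22 nM, while compound 1 `CC(C)c1n[nH]c2c(NCc3ccc(-c4ccccn4)cc3)nc(SC(CO)C(C)C)nc12` reads 980 nM. The step of a 45-fold lower number from compound 1 to compound 2 (1.65 log units; beyond the scatter) is the only measured one, and it replaced a branched hydroxyalkyl group with an aminoethyl group. Compound 3 `CC(C)c1n[nH]c2c(NCc3ccc(-c4ccccn4)cc3)nc(SC3CCCCC3N)nc12` keeps the amine but closes the chain into a ring: 2-aminocyclohexyl in place of 2-aminoethyl on a sulfur. Among the measured compounds shown here, no measured step shows the effect of such a ring, so only a small shift is expected, a 1.8-fold higher number from compound 2 to compound 3 (0.26 log units; within the scatter). Compound 3 is therefore estimated at 40 nM, within 10 nM to 160 nM.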

Compound 3, concentration for 50% growth inhibition: 139 nM
The estimate for compound 3 lay 3.5-fold (0.54 log units) below the measured number; low and high end bracket the measured number.
By their numbers in this assay, from the lowest: compound 2; then compound 3; then compound 1.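

In this assay, closing the amine chain into a ring on the sulfur weakens growth inhibition, with a 6.3-fold higher number from compound 2 to compound 3 (0.80 log units; beyond the scatter), so this position is sensitive to the shape of the group as well as to the presence of an amine. Even so, 2-aminocyclohexyl still outperforms the branched hydroxyalkyl group, with a 7.1-fold lower number from compound 1 to compound 3 (0.85 log units; beyond the scatter).

Still open, as far as these compounds go, is whether a smaller ring, such as 2-aminocyclopentyl, or a longer chain, such as 3-aminopropyl, would match or beat 2-aminoethyl. No available evidence explains the shift caused by the ring.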